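This account rests on a few compounds, and the source may have more. Where it says the series, first, only, none or still open, it means among the compounds named here.

Measured compounds:

compound 1, `O=S(=O)(/C=C/c1ccc(O)c(O)c1)Cc1ccccc1`, gives 11600 nM in a functional assay on BV-2 cells (Mus musculus) for inhibition, read by Griess assay, with stated times of 3 h and 24 h; a higher number here means a weaker inhibitor, a lower number a stronger inhibitor
compound 2, `O=S(=O)(/C=C/c1ccc(O)c(O)c1)CCCCc1ccccc1`, gives 19800 nM in this assay
compound 3, `O=S(=O)(/C=C/c1ccc(O)c(O)c1)Cc1ccc(Cl)cc1`, gives 11700 nM in this assay

Compound 1 has the lowest of the three numbers, yet its nearest neighbour, compound 3, is within the scatter of it, and so is the furthest, compound 2, so none of the three can be ranked against the others.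

Compound 4, `COc1ccc(CS(=O)(=O)/C=C/c2ccc(O)c(O)c2)cc1`, differs from compound 1 in one place: methoxy in place of hydrogen on an aromatic carbon. Going by the values given here, one measured step bears directly on this change. It also places a group on the same aromatic carbon of the same ring, with a chlorine instead of a methoxy: a 1.0-fold higher number from compound 1 to compound 3 (0.00 log units; within the scatter), no movement at all. Compound 2 alters a different part of the molecule, the chain between the sulfonyl and the phenyl ring, and its value beside that of compound 1 shows only that both lie within the scatter.

On this evidence, the step of a 1.0-fold higher number from compound 1 to compound 4 (0.01 log units; within the scatter) is expected to stay within the scatter, in no clear direction. Compound 4 is therefore estimated at 12000 nM in this assay, with a likely range of 6000 nM to 25000 nM.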

Compound 4, half-maximal inhibitory concentration in the BV-2 assay: 11900 nM
Estimate against measurement, compound 4: 1.0-fold (0.00 log units) above, and the stated range covers the measured number.
By their numbers in the BV-2 assay, from the lowest: compounds 1, 3, 4 and 2 (each within the scatter of the next).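

Going by these compounds alone, in the BV-2 assay the earlier compounds offered only one group at this aromatic carbon, para to a large group, and the methoxy now adds a second one, with 2 heavy atoms (1 carbon, 1 oxygen) and 1 hydrogen-bond acceptor, yet its step (a 1.0-fold higher number from compound 1 to compound 4 (0.01 log units; within the scatter)) also lies within the scatter. The direct swap of one group for the other in the BV-2 assay (a 1.0-fold higher number from compound 3 to compound 4 (0.01 log units; within the scatter)) lies within the scatter too, so this read-out does not separate hydrogen, chloro and methoxy at this carbon. The same change can also be read in a physicochemical assay for permeability, using PAMPA, with a stated time of 18 h, tested at 5 mg/mL (on this read-out higher numbers stand for higher permeability and lower numbers for lower permeability), where compound 1 gives 10.1 10^-6 cm/s and compound 4 gives 6.4 10^-6 cm/s (a 1.6-fold lower number from compound 1 to compound 4 (0.20 log units; within the scatter)), and there too the step lies within the scatter, so neither read-out separates compound 1 from compound 4.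

Still open, going by these compounds, is whether a group of another kind on this carbon, such as an amine or a carboxylic acid, would also stay within the scatter of compound 1, or whether these groups would behave the same way on the other carbons of this ring. Nothing shown here offers an explanation for these results.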